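The source may hold more compounds than are shown below. What is called first, only, known or untested is meant among the compounds shown, and "the series" means these compounds.

Working notes on the series. The shared core of compound 1 `Cc1cc(NC(=O)Cn2nnc(-c3cccnc3)n2)n(C2CCCCC2)n1` carries a five-membered aromatic ring that bears a varied aryl group. In an assay on HEK293 cells for activation of Kir3.1/Kir3.2 (Homo sapiens), read by thallium flux (on this read-out lower numbers stand for an effect already at smaller amounts and higher numbers for an effect only at larger amounts of compound), compound 1 gives 1930 nM. Compound 2 `Cc1cc(NC(=O)Cn2nnc(-c3ccccn3)n2)n(C2CCCCC2)n1` gives 14600 nM in this assay, and compound 3 `Cc1cc(NC(=O)Cn2nnc(-c3cccc(Cl)c3)n2)n(C2CCCCC2)n1` gives 300 nM. Compound 3 stands lowest of the three numbers; the steps of a 6.4-fold lower number from compound 1 to compound 3 (0.81 log units; beyond the scatter) and a 49-fold lower number from compound 2 to compound 3 (1.69 log units; beyond the scatter) set it apart from both, and the step of a 7.6-fold higher number from compound 1 to compound 2 (0.88 log units; beyond the scatter) separates the other two.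

Compound 4 `Cc1cc(NC(=O)Cn2nnc(-c3ccc(Cl)c(Cl)c3)n2)n(C2CCCCC2)n1` differs from compound 3 by chloro in place of hydrogen on an aromatic carbon; cut one bond further out, the change reads 3-chlorophenyl to 3,4-dichlorophenyl. Among the measured compounds shown here, no measured step adds a second chloro to the aryl group, so the steps that bear on it only indirectly are the step from pyridin-3-yl to 3-chlorophenyl and the step from pyridin-2-yl to 3-chlorophenyl, both going to lower numbers. On that footing a small step, most likely to a lower number but possibly within the scatter, is expected in this assay, as a 1.5-fold lower number from compound 3 to compound 4 (0.18 log units; within the scatter). Compound 4 is therefore estimated at 200 nM in this assay, with a range of 70 nM to 600 nM.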

Compound 4, half-maximal effective concentration: 1220 nM
Estimate against measurement, compound 4: 6.1-fold (0.79 log units) below; the whole stated range lies below it.
By their numbers in this assay, from the lowest: compound 3; then compounds 4 and 1 (each within the scatter of the next); then compound 2.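

Adding chloro to compound 3, ortho to its chloro group and para to the large group, does not extend the gain seen on going from the pyridyl groups to 3-chlorophenyl in this assay but gives a 4.1-fold higher number from compound 3 to compound 4 (0.61 log units; beyond the scatter), so compound 4 goes against any reading that more chloro on this aryl group lowers the number. The dichlorinated aryl group still keeps a 12-fold lower number from compound 2 to compound 4 (1.08 log units; beyond the scatter), while a 1.6-fold lower number from compound 1 to compound 4 (0.20 log units; within the scatter) leaves it level with pyridin-3-yl, and the advantage of compound 3 over compound 1 is lost with this one added atom. No measurement on hand bears on the reason for this result.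

From the compounds shown here alone, whether the rise is specific to chloro at this place remains open, since fluoro, methyl or methoxy there could behave differently. A 4-chlorophenyl group would show whether this place tolerates chloro on its own.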